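A few compounds are considered here, and "the series" means these few. Any claim that something is new, unique, unknown or untested is made for them only; others in the source may bear on it.

Compound 1 `N#CCCn1nc(-c2ccc(OCc3ccccc3)cc2)oc1=O` and compound 2 `Cc1cccc(COc2ccc(-c3nn(CCC#N)c(=O)o3)cc2)c1` share one core and differ only in a single group. In an assay on the whole organism for inhibition of Amine oxidase [flavin-containing] B (Rattus norvegicus), with a stated time of 24 h, at a dose of 5 mg/kg by the oral route (a higher number here means more inhibition at the dose given (going by the name of the read-out), a lower number less inhibition), compound 1 gives 18%, while in this assay compound 2 gives -3%. Within the data shown here, the one measured step, a number 21 percentage points lower from compound 1 to compound 2 (beyond the scatter), is the only change recorded so far. On these two numbers compound 2 stands lowest, with compound 1 the nearest neighbour and the only other point.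

Compound 3 `Cc1ccc(COc2ccc(-c3nn(CCC#N)c(=O)o3)cc2)cc1` is the next compound, not yet measured. It differs from compound 2 by 4-methylphenyl in place of 3-methylphenyl on a saturated chain carbon bound to an oxygen on an aromatic ring: the methyl stays on the same ring but moves to another carbon. Among the measured compounds shown here, no measured step covers such a move; the step from compound 1 to compound 2 tells what adding a methyl did, not what shifting it does. With nothing to set a direction, the expected step of a number 8 percentage points higher from compound 2 to compound 3 (within the scatter) is estimated to stay within the usual scatter. Compound 3 is therefore expected to give about 5% in this assay, with a range estimated from -12% to 22%.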

Compound 3, a percentage reported as inhibition, in the whole organism at one dose (the size of the read-out at that dose, not a potency): -3%
Compound 3: the middle estimate sits 8 percentage points above what was measured; measured number inside the range.
By their numbers in this assay, from the lowest: compounds 2 and 3 (each within the scatter of the next); then compound 1.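

Placing the methyl differently on the ring, as 4-methylphenyl in place of 3-methylphenyl on a saturated chain carbon bound to an oxygen on an aromatic ring, gives no change at the digits printed from compound 2 to compound 3 (within the scatter) in this assay, so this move leaves no readable mark on this read-out. The second methylated compound also lies clearly apart from the compound without a methyl, with a number 21 percentage points lower from compound 1 to compound 3 (beyond the scatter), a step of the same size as a number 21 percentage points lower from compound 1 to compound 2 (beyond the scatter); among these three compounds, then, having a methyl on this ring counts for more than which of the two ring carbons carries it, and no compound here goes against that. Nothing available explains why the methyl goes with a lower number or why moving it changes nothing.

Three compounds cannot show whether the lower number belongs to the methyl alone or would also appear with a fluorine atom or a methoxy group on the same ring. Also open, going by these compounds, is how the number would respond to a change elsewhere, such as a carboxylic acid in place of the nitrile on the chain.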